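The compounds below may be only part of what the source reports. "The series", "measured", "known", "first", "only" and "open" are said of these compounds alone.

Measured compounds:
compound 1 `COc1ccc(-c2c(C)nn(-c3nc(-c4ccc(Cl)c(Cl)c4)c(SC(C)C)s3)c2C(=O)O)cc1` — 2100 nM
compound 2 `Cc1nn(-c2nc(-c3ccc(Cl)c(Cl)c3)c(SC(C)C)s2)c(C(=O)O)c1-c1cccc(Cl)c1C` — 5100 nM
compound 3 `COc1cc(C#N)cc(-c2c(C)nn(-c3nc(-c4ccc(Cl)c(Cl)c4)c(SC(C)C)s3)c2C(=O)O)c1` — 5200 nM

These three compounds share one core and differ only in the aryl group on the five-membered aromatic ring with 2 nitrogen. In a functional assay on BJAB cells (Homo sapiens) for antiproliferative activity, with a stated time of 4 days (on this read-out higher numbers stand for an effect only at larger amounts of compound and lower numbers for an effect already at smaller amounts), compound 3 gives the highest of the three numbers, yet its distance to compound 2 is negligible: a 1.0-fold higher number from compound 2 to compound 3 (0.01 log units; within the scatter). Against compound 1 the gap is real: a 2.5-fold higher number from compound 1 to compound 3 (0.39 log units; beyond the scatter), and compound 2 stands off compound 1 by a similar amount: a 2.4-fold higher number from compound 1 to compound 2 (0.39 log units; beyond the scatter).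

Compound 4 `Cc1nn(-c2nc(-c3ccc(Cl)c(Cl)c3)c(SC(C)C)s2)c(C(=O)O)c1-c1ccncc1` has not yet been measured. The change from compound 3 is pyridin-4-yl in place of 3-cyano-5-methoxyphenyl on an aromatic carbon. Among the compounds with values here, none of the measured steps puts a pyridin-4-yl at this position, so the closest guide is the spread of the three aryl groups already tried, which covers only a modest range. A six-membered aromatic ring with 1 hetero atom is a different kind of group from any tried here, and it could move the number in either direction, while the scatter of the measurement adds further uncertainty. For compound 4 the expected step is therefore a 1.3-fold lower number from compound 3 to compound 4 (0.11 log units; within the scatter), with no firm direction. Compound 4 is thus estimated at 4000 nM, most likely between 1500 nM and 12000 nM.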

Compound 4, half-maximal effective concentration: 5900 nM
Compound 4: the middle estimate sits 1.5-fold (0.17 log units) below what was measured, and the stated range covers the measured number.
By their numbers in this assay, from the lowest: compound 1; then compounds 2, 3 and 4 (each within the scatter of the next).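

The 3-cyano-5-methoxyphenyl group leaves with its nitrile and methoxy group, and the smaller pyridin-4-yl brings a ring nitrogen, yet this assay shows a 1.1-fold higher number from compound 3 to compound 4 (0.05 log units; within the scatter) for this change. Measured against the 3-chloro-2-methylphenyl group, the same ring gives a 1.2-fold higher number from compound 2 to compound 4 (0.06 log units; within the scatter). Compounds 2, 3 and 4 thus form one group, with a nitrogen-containing ring now represented at this position alongside carbon-only rings. Compound 1 remains apart, with a 2.8-fold higher number from compound 1 to compound 4 (0.45 log units; beyond the scatter) here as well, so the 4-methoxyphenyl group is still the only one of the four aryl groups whose number separates from the rest, and nothing available explains any of these numbers.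

What a plain phenyl or a 4-hydroxyphenyl would give at this position remains open, so the compounds shown cannot tell whether the lower number of compound 1 goes with its methoxy group or with where that group sits on the ring. Also open, as far as these compounds go, is whether this position needs an aromatic ring at all, which a group such as a piperidine or a short alkyl chain could test.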